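This account rests on a few compounds, and the source may have more. Where it says the series, first, only, none or still open, it means among the compounds named here.

Measured compounds in an ADME assay on MDCKII-LE cells (Canis lupus familiaris) for permeability, in the apical to basolateral direction; on this read-out higher numbers stand for higher permeability and lower numbers for lower permeability:

compound 1, `COc1cccc(NS(=O)(=O)c2cc3c(cc2Cl)NC(=O)CO3)c1`, gives 8.8 10^-6 cm/s
compound 2, `O=c1cc(Cn2cnc3ccccc32)nc2sccn12`, gives 17.3 10^-6 cm/s

Two compounds with unrelated cores have been run in this assay. Compound 2 is the one followed here; its number and that of compound 1 differ by an amount that stays within the usual scatter of repeated measurements, so the two are not to be ordered against each other, and neither can be called the more permeable. Within the data shown here, no pair that differs in a single place has been measured, so there is no step in this assay to lean on.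

Compound 3, `O=c1cc(Cn2cnc3ccccc32)nc2scc(-c3ccccc3)n12`, is the next compound for this assay. Its difference from compound 2 is phenyl in place of hydrogen on an aromatic carbon.

With no measured step of this kind in the series, the size of the change can only be guessed. Compound 3 is expected to give 20 10^-6 cm/s, with a range from 8 10^-6 cm/s to 40 10^-6 cm/s. That estimate means a step of a 1.2-fold higher number from compound 2 to compound 3 (0.06 log units; within the scatter), a shift that would lie within or only just beyond the scatter and so is not claimed as a real change in either direction.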

Compound 3, apparent permeability: 11.5 10^-6 cm/s
Compound 3: middle estimate off by 1.7-fold (0.24 log units), on the high side, and the stated range covers the measured number.
By their numbers in this assay, from the lowest: compounds 1, 3 and 2 (each within the scatter of the next).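

The first single-place step in this assay is a 1.5-fold lower number from compound 2 to compound 3 (0.18 log units; within the scatter) and it stays within the usual scatter, so phenyl in place of hydrogen at this position is not shown to move the read-out in either direction. This aromatic carbon, next to the ring nitrogen and two ring bonds from the ring sulfur, therefore carries a group of 6 heavy atoms with no change that can be told apart from repeat measurements, though this rests on a single pair and is no trend. No measured property of the compounds bears on this result, so the step stands without an explanation.

Whether this position stays as flat with other groups is open: an amine, a carboxylic acid or a short alkyl chain on the same aromatic carbon would show whether the read-out can move at this place at all. Also open, going by these compounds, is whether a methoxy group or a chlorine atom on the added phenyl would leave the number within the scatter of compound 3.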